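Weak Cytotoxicity Holds Across Thioether Side Chains

The compounds below may be only part of what the source reports. "The series", "measured", "known", "first", "only" and "open" are said of these compounds alone.

Within the data shown here, compound 2 `Cc1cc(N2CC[C@@H](C)[C@@H](N(C)c3ncnc4[nH]ccc34)C2)n2nc(SCC3CCCCC3)nc2n1` is the one compound of this set for which a toxicity assay on GES1 cells (Homo sapiens) for inhibition, read by MTT assay, with a stated time of 72 h (a lower number here means a stronger inhibitor, a higher number a weaker inhibitor), returns a number rather than a limit: in this assay compound 2 gives 98200 nM. Its two neighbours sit at a limit. Compound 1 `Cc1cc(N2CC[C@@H](C)[C@@H](N(C)c3ncnc4[nH]ccc34)C2)n2nc(SCc3csc4ccc(Cl)cc34)nc2n1` reaches only the limit > 100000 nM in this assay. Compound 3 `CCCCCc1c(C)nc2nc(SCc3ccc(Cl)cc3)nn2c1N1CC[C@@H](C)[C@@H](N(C)c2ncnc3[nH]ccc23)C1` likewise stops at the limit > 100000 nM in this assay. Among the measured compounds shown here, the single measured step, an at least 1.0-fold lower number from compound 1 to compound 2 (0.00 log units; that floor lies within the scatter), lies within the scatter, and the set as a whole is marked by the limit of > 100000 nM in this assay, at which 2 of the 3 values shown sit.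

Compound 4 `Cc1cc(N2CC[C@@H](C)[C@@H](N(C)c3ncnc4[nH]ccc34)C2)n2nc(SCCCc3ccccc3)nc2n1` differs from compound 2 by phenethyl in place of cyclohexyl on a saturated chain carbon bound to a sulfur. For the measured compounds named here, the only step touching this position, an at least 1.0-fold lower number from compound 1 to compound 2 (0.00 log units; that floor lies within the scatter), altered the number by no more than the scatter, so a step in this assay of any size beyond the scatter is not indicated in either direction. Compound 4 is therefore expected to show a 1.0-fold higher number from compound 2 to compound 4 (0.01 log units; within the scatter), amounting to no change beyond the scatter. The value of compound 4 in this assay is estimated at 100000 nM, within 50000 nM to 200000 nM, with a fair chance that only a limit is reported.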

Compound 4, half-maximal inhibitory concentration: > 100000 nM
Compound 4 ended at the assay's limit; the forecaster's own chance of this, stated with the estimate: 60%; the middle value sits exactly at the limit.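

As far as these compounds go, changing the group on a saturated chain carbon bound to a sulfur from cyclohexyl to phenethyl, which puts a six-membered aromatic ring of carbon only where a non-aromatic one stood, gives in this assay an at least 1.0-fold higher number from compound 2 to compound 4 (0.00 log units; that floor lies within the scatter), so this second step at the position also shows no change beyond the scatter, though its true size stays open on the upper side. The comparison of compound 1 with compound 4 cannot be read, since both compounds stop at a limit of the assay. With a third side chain now added, the position has carried a fused sulfur-containing aromatic group, a saturated ring and a 3-phenylpropyl chain, and the values gather at one limit: the limit of > 100000 nM in this assay, at which 3 of the 4 values shown sit.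

The compounds shown leave open whether a side chain ending in an amine or a carboxylic acid at this position would bring a clearly lower number in this assay. They also leave open how far compound 4 lies from compound 2, as the reading for compound 4 is a limit and not a number.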